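Chloro to methyl: expected cytotoxicity of compound 4

The compounds below may be only part of what the source reports. "The series", "measured", "known", "first", "only" and "open" are said of these compounds alone.

Measured in an ADME assay on MT4 cells (Homo sapiens) for cytotoxicity; a lower number here means that less compound is tolerated, a higher number that more compound is tolerated:
- compound 1 `O=c1[nH]c2ccc(Cl)cc2n1Cc1c(F)cccc1F`: > 424000 nM (a limit)
- compound 2 `CC(=O)n1c(=O)n(Cc2c(F)cccc2F)c2cc(Cl)ccc21`: > 5950 nM (a limit)
- compound 3 `Cc1cc(C)cc(Cn2c(=S)[nH]c3ccc(Cl)cc32)c1`: 305 nM

Compound 1 has no exact number and stands at the limit of > 424000 nM in this assay, at which 1 of the 3 values shown sits. Compound 2 also gives only a limit, > 5950 nM. Within the data shown here, compound 3 is the only one with a true number, 305 nM, but no step confined to one place links it to compound 1, so it gives no size for the change considered here.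

The next compound is compound 4 `Cc1ccc2[nH]c(=O)n(Cc3c(F)cccc3F)c2c1`, which differs from compound 1 as follows: methyl in place of chloro on an aromatic carbon. Among the measured compounds shown here, the only measured step is a step that the two limits leave unreadable from compound 1 to compound 2. That step concerns acetyl in place of hydrogen on an aromatic nitrogen, a different change at a different place, so it offers no size to carry over.

The expectation therefore rests on compound 1 alone, whose > 424000 nM is a limit. No step beyond the usual scatter is expected in this assay, and compound 4 may also be reported only as a limit. The estimated change is an at least 1.4-fold lower number from compound 1 to compound 4 (0.15 log units; that floor lies within the scatter). Compound 4 is expected at 300000 nM, with an estimated range of 60000 nM to 450000 nM.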

Compound 4, half-maximal cytotoxic concentration: 236000 nM
The estimate for compound 4 lay 1.3-fold (0.10 log units) above the measured number, and the stated range covers the measured number.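

In this assay, the swap of chloro for methyl on this aromatic carbon gives the first readable size for a change to compound 1: an at least 1.7-fold lower number from compound 1 to compound 4 (0.25 log units; that floor lies within the scatter). Because that floor lies within the scatter, the swap is not shown to have any real effect on tolerance at this position, and the data only show that the methyl compound can be read on the scale at all. Among these compounds, compound 4 gives an exact number, 236000 nM, which makes it the first compound with this shared core to offer a true reference point. Compound 1 and compound 2 give only limits, and the step from compound 1 stays a floor because compound 1 has no exact number: the limit of > 424000 nM in this assay, at which 1 of the 4 values shown sits.

As far as these compounds go, the true size of the step from chloro to methyl stays open, as does the unreadable step to the acetyl compound, since neither can be read beyond what these limits allow. From the compounds shown here alone, how an amine, a carboxylic acid or a longer chain such as propyl on this same aromatic carbon would read in this assay also remains open.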